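A few compounds are considered here, and "the series" means these few. Any claim that something is new, unique, unknown or untested is made for them only; others in the source may bear on it.

Going by the values given here, compound 3 `COc1ccccc1-c1cccc2nc(Nc3cc(OC)c(OC)c(OC)c3)oc12` is the one measured compound with a readable number in an assay on BAF cells for inhibition of ribosomal protein S6 kinase alpha-2 (Mus musculus); a higher number here means a weaker inhibitor, a lower number a stronger inhibitor: compound 3 gives 5700 nM. Compound 1 `COc1cccc(F)c1-c1cccc2nc(N)oc12` reaches only the limit of the assay, > 20000 nM. Compound 2 `COc1cccc(Nc2nc3cccc(-c4c(F)cccc4OC)c3o2)n1` also reaches only the limit, > 20000 nM. The measured set therefore rests mostly on (the limit of > 20000 nM in this assay, at which 2 of the 3 values shown sit). Compound 4 `COc1cc(Nc2nc3cccc(-c4c(F)cccc4OC(C)C)c3o2)cc(OC)c1OC` is not yet measured and differs from compound 3 in one place: a group of 11 heavy atoms (9 carbon, 1 oxygen, 1 fluorine; one six-membered aromatic ring of carbon only) in place of a group of 8 heavy atoms (7 carbon, 1 oxygen; one six-membered aromatic ring of carbon only), on an aromatic carbon. The step from compound 1 to compound 2 alters a different part of the molecule and is not readable, a step that the two limits leave unreadable from compound 1 to compound 2. Among the compounds with values here, no measured step covers the change from compound 3 to compound 4, and nothing in the numbers points to a shift beyond the scatter. Compound 4 is thus estimated at 6000 nM, between 1500 nM and 20000 nM, which means an expected step of a 1.1-fold higher number from compound 3 to compound 4 (0.02 log units; within the scatter).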

Compound 4, half-maximal inhibitory concentration: > 20000 nM
Compound 4: a limit, no number; the forecaster's own chance of this, stated with the estimate: 25%; at least 3.3-fold (0.52 log units) between middle value and limit.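

Going by these compounds alone, this position on the shared core does respond to change, which the earlier compounds could not show: in this assay, putting the group of 11 heavy atoms in place of 2-methoxyphenyl gives an at least 3.5-fold higher number from compound 3 to compound 4 (0.54 log units; beyond the scatter). The entering group adds fluorine and extra carbon together, so this one step cannot separate their contributions. The true size of the loss also stays unknown, since compound 4 gives only a limit: the limit of > 20000 nM in this assay, at which 3 of the 4 values shown sit.

The step from compound 1 to compound 2 cannot be read. Going by these compounds, how a phenyl ring carrying an amine or a carboxylic acid would behave at this position remains open.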